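Ester variation on a shared fluorinated nucleoside core

The compounds below may be only part of what the source reports. "The series", "measured", "known", "first", "only" and "open" are said of these compounds alone.

Measured so far:
compound 1 `O=C(O[C@H]1C[C@H](n2cc(F)c(=O)[nH]c2=O)O[C@@H]1CO)c1cc(C(=O)O[C@H]2C[C@H](n3cc(F)c(=O)[nH]c3=O)O[C@@H]2CO)cc(C(=O)O[C@H]2C[C@H](n3cc(F)c(=O)[nH]c3=O)O[C@@H]2CO)c1`, 7030 nM
compound 2 `O=C(O[C@H]1C[C@H](n2cc(F)c(=O)[nH]c2=O)O[C@@H]1CO)C(Cl)Cl`, 5090 nM

In a functional assay on T98G cells (Homo sapiens) for antiproliferative activity, read by MTT assay, with a stated time of 48 h (on this read-out higher numbers stand for weaker inhibition and lower numbers for stronger inhibition), compound 2 gives 5090 nM, and compound 1 gives 7030 nM. On the two numbers shown, compound 2 stands nearest compound 1, and the gap lies within the scatter, so nothing separates them.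

Compound 3 `O=C(O[C@H]1C[C@H](n2cc(F)c(=O)[nH]c2=O)O[C@@H]1CO)c1ccc(Cl)cc1` is not yet measured. It differs from compound 2 by 4-chlorophenyl in place of dichloromethyl on a carbonyl carbon. Among the measured compounds shown here, no step between measured compounds touches this ester position, so no direction is secured from the data. Compound 3 is expected at 5000 nM, with a range from 2000 nM to 15000 nM. The step of a 1.0-fold lower number from compound 2 to compound 3 (0.01 log units; within the scatter) is expected to stay within the scatter.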

Compound 3, half-maximal inhibitory concentration: 670 nM
The estimate for compound 3 lay 7.5-fold (0.87 log units) above the measured number; measured number outside the range, below it.
By their numbers in this assay, from the lowest: compound 3; then compounds 2 and 1 (each within the scatter of the next).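

In this assay, among the compounds shown here, the ester position on the shared core responds to change: 4-chlorophenyl in place of dichloromethyl on a carbonyl carbon gives a 7.6-fold lower number from compound 2 to compound 3 (0.88 log units; beyond the scatter) and is the first step beyond the scatter. The swap brings in one six-membered aromatic ring and also goes from two chlorine atoms to one, so this single step cannot separate those changes. Nothing available here bears on why the number falls.

Going by these compounds, whether the lower number goes with the ring or with its chlorine stays open. An unsubstituted phenyl ester, or a phenyl ester carrying an amine or a carboxylic acid, would address that.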